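Compound 3 and the expected potency of compound 4

The source may hold more compounds than are shown below. What is called first, only, known or untested is meant among the compounds shown, and "the series" means these compounds.

Among the measured compounds shown here, compound 3 `Nc1[nH]c(C(=O)c2ccccc2)c(-c2ccc(Cl)cc2Cl)c1C(=O)c1ccc(Cl)c(Cl)c1` is the only compound here with a numeric value: in an assay for inhibition of Polyunsaturated fatty acid lipoxygenase ALOX15 (Homo sapiens), with a stated time of 10 min (on this read-out higher numbers stand for weaker inhibition and lower numbers for stronger inhibition), compound 3 gives 12800 nM. Compound 1 `Nc1[nH]c(C(=O)c2ccccc2)c(-c2cccc3ccccc23)c1C(=O)c1ccc(Cl)c(Cl)c1` reaches only the limit of this assay, > 100000 nM. Compound 2 `Nc1[nH]c(C(=O)c2ccccc2)c(-c2ccc(Cl)cc2Cl)c1C(=O)c1ccccc1` likewise reaches only the limit, > 100000 nM. Both steps into compound 3 are therefore lower bounds, an at least 7.8-fold lower number from compound 1 to compound 3 (0.89 log units; beyond the scatter) and an at least 7.8-fold lower number from compound 2 to compound 3 (0.89 log units; beyond the scatter), consistent with the limit of > 100000 nM in this assay, at which 2 of the 3 values shown sit.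

Compound 4 `Nc1[nH]c(C(=O)c2ccccc2)c(-c2c(F)cccc2F)c1C(=O)c1ccc(Cl)c(Cl)c1` differs from compound 3 in one place: 2,6-difluorophenyl in place of 2,4-dichlorophenyl on an aromatic carbon. The step from compound 1 to compound 3 concerns this same place and shows that changing the aryl group there can shift the number by at least a modest amount. Compound 4 is expected to give about 40000 nM in this assay, between 10000 nM and 150000 nM. This expectation corresponds to a step of a 3.1-fold higher number from compound 3 to compound 4 (0.49 log units; beyond the scatter), weaker and with a real chance of reaching only the limit.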

Compound 4, half-maximal inhibitory concentration: > 100000 nM
Compound 4: only a limit was reported (the forecaster's own chance of this, stated with the estimate: 40%); middle value at least 2.5-fold (0.39 log units) from the limit.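

In this assay, 2,6-difluorophenyl in place of 2,4-dichlorophenyl gives an at least 7.8-fold higher number from compound 3 to compound 4 (0.89 log units; beyond the scatter), a lower bound. So this position is sensitive not only to replacing naphthalen-1-yl, as seen earlier, but also to a change between two substituted phenyl groups with the same count of heavy atoms. Compound 4 joins the compounds that reach only the limit: the limit of > 100000 nM in this assay, at which 3 of the 4 values shown sit. The step between compound 1 and compound 4 cannot be read, since both values are limits. The compounds shown leave open whether the halogen or its placement matters, and how 2,4-difluorophenyl or 4-methoxyphenyl would read here.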